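The source may report more compounds than this note shows. Statements on the series, on what has been measured and on what is new or still open speak of the compounds shown alone.

Three related compounds have been measured in a functional assay on BEAS-2B cells (Homo sapiens) for inhibition, read by MTT assay, with a stated time of 72 h; on this read-out lower numbers stand for stronger inhibition and higher numbers for weaker inhibition. Compound 1 (`C=C(c1ccc(Cl)c(Cl)c1)C1COC2(CCCCC2)OO1`) gives 39400 nM. Compound 3 (`C=C(c1ccc(F)c(F)c1)C1COC2(CCCCC2)OO1`) gives 61200 nM, which lies within the usual scatter of the value for compound 1, so these two cannot be told apart. Compound 2 (`C=C(c1ccc(Cl)c(Cl)c1Cl)C1COC(C)(C)OO1`) gives 10200 nM, a number clearly lower than that of compound 1, beyond the scatter. Compound 1 therefore stands level with compound 3 and on the weaker side of compound 2.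

Compound 4 (`C=C(c1ccc(Cl)c(Cl)c1Cl)C1COC2(CCCCC2)OO1`) has not yet been measured. It differs from compound 1 by a single change, chloro in place of hydrogen on an aromatic carbon, ortho to a chloro group and to a large group, and meta to a further chloro group. Within the data shown here, no measured pair shows this change on its own, so any forecast is loose. The lower number of compound 2, at 10200 nM, gives a modest reason to lean downward. In this assay a small downward move is expected, probably no larger than the scatter, and the estimated change is a 1.6-fold lower number from compound 1 to compound 4 (0.20 log units; within the scatter). For compound 4 the estimated value is 25000 nM, with an expected range from 9000 nM to 60000 nM.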

Compound 4, half-maximal inhibitory concentration: 10300 nM
Beside the measured number, compound 4's estimate is 2.4-fold (0.39 log units) above it; measured number inside the range.
By their numbers in this assay, from the lowest: compounds 2 and 4 (each within the scatter of the next); then compounds 1 and 3 (each within the scatter of the next).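

In this assay, a chloro group in place of hydrogen on the aromatic carbon ortho to a chloro group and to a large group, and meta to a further chloro group, gives a 3.8-fold lower number from compound 1 to compound 4 (0.58 log units; beyond the scatter). Among these compounds, this is the first single change seen at this position, and it shows that hydrogen and chloro on this carbon can be told apart in this cell read-out, although the finding rests on just one pair of compounds. No measurement shown here accounts for the size of the step or says what the added chloro group does in the cells.

A methyl or methoxy group, or a bromo or fluoro atom, on the same carbon would show whether the lower number is particular to chloro or also appears with other groups. Compound 2 carries the same chloro pattern on a different remainder of the molecule, but its partner with hydrogen on this carbon is not among the compounds shown, so it remains open whether the step carries over to that background.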